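The source may hold more compounds than are shown below. What is called first, only, known or untested is meant among the compounds shown, and "the series" means these compounds.

Measured compounds:
compound 1 `CCCc1nc2c(C)cc(C)nc2n1Cc1ccc(-c2c(C(=O)O)c(N)nc3ccccc23)cc1`: 520 ng.h/mL
compound 2 `CCc1nc2c(C)cc(C)nc2n1Cc1ccc(-c2c(C(=O)O)n(C)c(=O)c3ccccc23)cc1`: 630 ng.h/mL

In an ADME assay on the whole organism (plasma, strain Sprague-Dawley) for pharmacokinetics, with Rattus norvegicus as the target, at a dose of 3 mg/kg by the intravenous route (on this read-out higher numbers stand for higher exposure at the dose given and lower numbers for lower exposure), compound 1 gives 520 ng.h/mL. Compound 2 gives 630 ng.h/mL in this assay, and the gap between these two numbers lies within the usual scatter of repeated measurements, so the pair cannot be told apart on this read-out. Compound 3 `CCCc1nc2c(C)cc(C)nc2n1Cc1ccc(-c2c(C(=O)O)c(C)nc3ccccc23)cc1` has not yet been measured in this assay. It differs from compound 1 in a single place: methyl in place of amino on an aromatic carbon. For the measured compounds named here, no pair of measured compounds shows a change of this kind, so the data give no direct guide to its size or direction. On that basis the exposure of compound 1 is expected to carry over to compound 3 with little alteration. The expected step, a 1.0-fold lower number from compound 1 to compound 3 (0.02 log units; within the scatter), is not thought to reach beyond the scatter. Compound 3 is accordingly estimated at 500 ng.h/mL, with a likely range from 200 ng.h/mL to 1300 ng.h/mL.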

Compound 3, area under the concentration-time curve: 500 ng.h/mL
Beside the measured number, compound 3's estimate shows no gap at the digits printed; the range from low to high includes it.
By their numbers in this assay, from the lowest: compounds 3, 1 and 2 (each within the scatter of the next).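

For the compounds shown here, the pair gives the first direct reading of a change at this position: in this assay, methyl in place of amino on an aromatic carbon, next to the ring nitrogen and ortho to a carboxy group, gives a 1.0-fold lower number from compound 1 to compound 3 (0.02 log units; within the scatter). On the core of compound 1, then, this position takes either group without a step beyond the scatter, even though the hydrogen-bond donor and hydrogen-bond acceptor counted on amino are absent from methyl. No measurement at hand bears on the reason for this result. As far as these compounds go, whether another group at this position, such as an ethyl chain, a hydroxyl or a chlorine atom, would also leave exposure within the scatter stays open. Compound 2 differs from compound 1 and compound 3 in more than one place, so it cannot show whether this change would behave alike on its core.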